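Swapping one amine ring system for another: expected inhibition

The compounds below may be only part of what the source reports. "The series", "measured", "known", "first", "only" and "open" are said of these compounds alone.

Compound 1 `CN1CCCN(c2ncc(Oc3cc(CN4CCC(CC(=O)O)CC4)cc(-c4cc(Cl)cc(Cl)c4)n3)cn2)CC1`: 34%
Compound 2 `CN1CCCN(c2cnc(Oc3cc(CN4CCC(CC(=O)O)CC4)cc(-c4cc(Cl)cc(Cl)c4)n3)cn2)CC1`: 26%

Of the compounds shown here, two have been tested in a functional assay on the whole organism for inhibition, with Mus musculus as the target, at a dose of 30 mg/kg by the oral route; a lower number here means less inhibition, a higher number more inhibition at the dose given (going by the name of the read-out). Compound 1 gives 34% in this assay, and compound 2 gives 26%. The gap between these two numbers lies within the usual scatter of repeated measurements, so the two results cannot be told apart and the inhibition in this assay is level for the two compounds on this evidence. Compound 1 is the starting point for the next step.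

Compound 3 `O=C(O)CC1CCN(Cc2cc(Oc3cnc(N4CCN5CCC4C5)nc3)nc(-c3cc(Cl)cc(Cl)c3)c2)CC1` has not yet been measured. It differs from compound 1 in one place: a group of 8 heavy atoms (6 carbon, 2 nitrogen; one five-membered non-aromatic ring with 1 hetero atom, one six-membered non-aromatic ring with 2 hetero atoms) in place of a group of 8 heavy atoms (6 carbon, 2 nitrogen; one seven-membered non-aromatic ring with 2 hetero atoms), on an aromatic carbon. The group that leaves and the group that enters have the same count of heavy atoms and the same counts of hydrogen-bond donors and acceptors; what changes is the shape of the ring system at that position.

Among the measured compounds shown here, no measured pair shows the effect of such a change, so the expectation rests on the two numbers at hand, which are close to each other. A step of no more than the usual scatter, in either direction, is the most reasonable expectation for compound 3 in this assay. Compound 3 is therefore estimated to give about 30%, with a range from 10% to 55%. This estimate implies a step of a number 4 percentage points lower from compound 1 to compound 3 (within the scatter) that is expected to stay within the scatter.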

Compound 3, a percentage reported as inhibition, in the whole organism at one dose (the size of the read-out at that dose, not a potency): 36%
Estimate against measurement, compound 3: 6 percentage points below; the range from low to high includes it.
By their numbers in this assay, from the lowest: compounds 2, 1 and 3 (each within the scatter of the next).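

Among the compounds shown here, the pair of compound 1 and compound 3 gives the first direct reading of a change at this position, the aromatic carbon between two ring nitrogen atoms. In this assay, replacing the 4-methyl-1,4-diazepan-1-yl group, with its one seven-membered ring, by the group with a five-membered and a six-membered non-aromatic ring gives a number 2 percentage points higher from compound 1 to compound 3 (within the scatter) and so leaves the two compounds indistinguishable: this redrawing of the ring system, with the same heavy-atom count and the same counts of donors and acceptors, has no effect that can be read in this whole-animal result at the one dose tested. Nothing measured here offers an explanation for this outcome, and none can be given.

A single pair cannot show whether other amines at this position, such as a piperazine ring, a morpholine ring or an open-chain dimethylamino group, would also stay level with compound 1. On these data alone, the read-out also gives the size of the inhibition at one dose rather than a potency, so any difference between compound 1 and compound 3 at other doses remains open.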